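Cyclobutyl for isobutyl on the amide carbonyl: cytotoxicity

The compounds below may be only part of what the source reports. "The series", "measured", "known", "first", "only" and "open" are said of these compounds alone.

Compound 3 `CC(C)CC(=O)N1CCN(c2nc(=O)c3cc(C(F)(F)F)cc([N+](=O)[O-])c3s2)CC1` is one of three amides built on a shared core. In an ADME assay on Vero cells (Chlorocebus sabaeus) for cytotoxicity, read by MTT assay, with a stated time of 72 h (a lower number here means that less compound is tolerated, a higher number that more compound is tolerated), compound 3 gives only a limit, > 125000 nM. Compound 1 `CC(=O)N1CCN(c2nc(=O)c3cc(C(F)(F)F)cc([N+](=O)[O-])c3s2)CC1` likewise returns a limit in this assay, > 125000 nM. Compound 2 `O=C(c1cccc(F)c1)N1CCN(c2nc(=O)c3cc(C(F)(F)F)cc([N+](=O)[O-])c3s2)CC1` also returns a limit, > 125000 nM. All three therefore sit at the limit of > 125000 nM in this assay, at which 3 of the 3 values shown sit. Compound 4 `O=C(C1CCC1)N1CCN(c2nc(=O)c3cc(C(F)(F)F)cc([N+](=O)[O-])c3s2)CC1` differs from compound 3 by cyclobutyl in place of isobutyl on a carbonyl carbon. The measured steps that bear on this change, a step that the two limits leave unreadable from compound 2 to compound 3 and a step that the two limits leave unreadable from compound 1 to compound 3, are both unreadable, so nothing in them points to a readable step in this assay in either direction. Compound 4 is therefore expected to remain at the limit, estimated at 125000 nM with a range from 60000 nM to 300000 nM. The expected step of a number no higher from compound 3 to compound 4 (the limit leaves the size open) is none beyond the scatter.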

Compound 4, half-maximal cytotoxic concentration: > 125000 nM
Compound 4: a limit, no number; the forecaster's own chance of this, stated with the estimate: 85%; the middle value sits exactly at the limit.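

In this assay compound 4 gives only a limit, > 125000 nM, so its steps from compound 1, compound 2 and compound 3 cannot be read. The compounds shown leave open whether any group on the carbonyl carbon changes this read-out at all: the limit of > 125000 nM in this assay, at which 4 of the 4 values shown sit.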